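The source may hold more compounds than are shown below. What is called first, only, known or untested is meant among the compounds shown, and "the series" means these compounds.

Compound 3 `COc1ccc(/C=C/C(=O)/C=C/c2ccc(OCc3cn(CCOc4cc(=O)oc5ccccc45)nn3)c(OC)c2)cc1` is the second highest of three compounds in a functional assay on COLO 205 cells (Homo sapiens) for inhibition, read by sulforhodamine B assay, with a stated time of 48 h, tested at 50 uM (on this read-out lower numbers stand for less inhibition of growth and higher numbers for more inhibition of growth at the one concentration tested), where compound 3 gives 68%. Compound 1 `COc1ccccc1/C=C/C(=O)/C=C/c1ccc(OCc2cn(CCOc3cc(=O)oc4ccccc34)nn2)c(OC)c1` gives 67%, and compound 2 `COc1cc(/C=C/C(=O)/C=C/c2cc(OC)c(OC)c(OC)c2)ccc1OCc1cn(CCOc2cc(=O)oc3ccccc23)nn1` gives 86%. Compound 4 `COc1cc(/C=C/C(=O)/C=C/c2ccccc2)ccc1OCc1cn(CCOc2cc(=O)oc3ccccc23)nn1` differs from compound 3 by hydrogen in place of methoxy on an aromatic carbon. Two measured steps alter the same ring: the step from compound 1 to compound 3 was a number 1 percentage points higher from compound 1 to compound 3 (within the scatter), while the step from compound 2 to compound 3, which put 4-methoxyphenyl in place of 3,4,5-trimethoxyphenyl, was a number 18 percentage points lower from compound 2 to compound 3 (beyond the scatter). Taking away the remaining methoxy may therefore lower growth inhibition again, though perhaps by less. The number for compound 4 is expected to be about 60%, between 45% and 75%. That estimate means a step of a number 8 percentage points lower from compound 3 to compound 4 (within the scatter).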

Compound 4, percent growth inhibition at one concentration: 54%
Beside the measured number, compound 4's estimate is 6 percentage points above it; the range from low to high includes it.
By their numbers in this assay, from the lowest: compound 4; then compounds 1 and 3 (each within the scatter of the next); then compound 2.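

Taking the last methoxy off this ring still counts: the change gives a number 14 percentage points lower from compound 3 to compound 4 (beyond the scatter) and so leaves no methoxy on that ring at all. The same bare phenyl ring gives a number 13 percentage points lower from compound 1 to compound 4 (beyond the scatter) when the single methoxy sits elsewhere on the ring, and the largest gap in the set is a number 32 percentage points lower from compound 2 to compound 4 (beyond the scatter). Among these four compounds, growth inhibition therefore rises from no methoxy to one to three, with compound 1 and compound 3 level. On these data alone, whether a hydroxy group or an amine on this ring could stand in for methoxy stays open. The data give no explanation for the drop.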